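The source may report more compounds than this note shows. Statements on the series, on what has been measured and on what is new or still open speak of the compounds shown alone.

Measured so far in an ADME assay on HEK293 cells (Homo sapiens) for cytotoxicity, read by resazurin assay, with a stated time of 48 h; on this read-out higher numbers stand for lower toxicity in this test and lower numbers for higher toxicity in this test:

Compound 1 `O=S(=O)(Nc1ccc(-c2nc3ccccc3o2)cc1)c1ccccc1O` — in this assay compound 1 gives > 100000 nM, a limit of the assay rather than a number.
Compound 2 `Cc1cccc(S(=O)(=O)Nc2ccc(-c3nc4ccccc4o3)cc2)c1` — in this assay compound 2 gives > 100000 nM, again a limit.
Compound 3 `O=S(=O)(Nc1ccc(-c2nc3ccccc3o2)cc1)c1ccc(F)cc1` — in this assay compound 3 gives > 100000 nM, also a limit.

Compound 3 therefore stands where every value shown stands: at the limit, with no number of its own. The three measured steps tell nothing readable — a step that the two limits leave unreadable from compound 1 to compound 2, a step that the two limits leave unreadable from compound 1 to compound 3 and a step that the two limits leave unreadable from compound 2 to compound 3 — because of the limit of > 100000 nM in this assay, at which 3 of the 3 values shown sit.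

The unmeasured compound is compound 4 `Cc1ccc(S(=O)(=O)Nc2ccc(-c3nc4ccccc4o3)cc2)cc1`. It differs from compound 3 in one place: methyl in place of fluoro on an aromatic carbon. Among the compounds with values here, two of the measured steps change the group on the same sulfonyl sulfur, yet neither has a readable size, so there is no measured precedent for the size of this step in this assay, only the observation that every variant so far has remained at the limit.

The expectation for compound 4 is accordingly an estimate of 150000 nM, with a range of 50000 nM to 500000 nM. The step that the limit leaves unreadable from compound 3 to compound 4 is expected to amount to nothing beyond the scatter, with a further limit the most likely outcome.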

Compound 4, half-maximal cytotoxic concentration: 88000 nM
Beside the measured number, compound 4's estimate is 1.7-fold (0.23 log units) above it; low and high end bracket the measured number.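

In this assay compound 4 is the only one of the four compounds shown that gives a number rather than a limit, and this makes the change at this place readable in one direction: methyl in place of fluoro, para to a large group, gives an at least 1.1-fold lower number from compound 3 to compound 4 (0.05 log units; that floor lies within the scatter). Against the other two compounds, the 4-methylphenyl group on the sulfonyl sulfur gives an at least 1.1-fold lower number from compound 2 to compound 4 (0.05 log units; that floor lies within the scatter), and it also gives an at least 1.1-fold lower number from compound 1 to compound 4 (0.05 log units; that floor lies within the scatter). All three floors lie within the scatter, so none of them establishes a real difference, and the true sizes stay unknown because the partner in each step carries no number of its own: the limit of > 100000 nM in this assay, at which 3 of the 4 values shown sit.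

As far as these compounds go, it remains open how an amine or a carboxylic acid at this place on the ring would read, and whether either would move the number beyond the scatter. Also open, from the compounds shown here alone, is how a longer chain in place of the methyl would read in this assay, and whether a change to the shared core would shift the number at all.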